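From 4-(dimethylamino)phenyl to phenyl on compound 1

The source may report more compounds than this note shows. Statements on the series, on what has been measured and on what is new or still open speak of the compounds shown alone.

Among the compounds with values here, in a functional assay on KB cells (Homo sapiens) for inhibition, with a stated time of 72 h (on this read-out lower numbers stand for stronger inhibition and higher numbers for weaker inhibition), compound 1 (`COc1ccc(S(=O)(=O)N2CCc3cccc(-c4ccc(N(C)C)cc4)c32)cc1`) gives 539 nM as its half-maximal inhibitory concentration, the lower of the two numbers so far. Compound 2 (`COc1ccc(S(=O)(=O)N2CCc3cccc(-c4c(F)c(F)c(F)c(F)c4F)c32)cc1`) gives 4040 nM and so reads higher, with a gap beyond the usual scatter.

Compound 3 (`COc1ccc(S(=O)(=O)N2CCc3cccc(-c4ccccc4)c32)cc1`) has not yet been measured. It differs from compound 1 in one place, on an aromatic carbon of a six-membered aromatic ring of carbon only, para to a large group, where hydrogen stands in place of dimethylamino (hydrogen in place of dimethylamino on an aromatic carbon). Within the data shown here, no measured pair shows this change alone, so the data give no direct size for it. Among the measured compounds shown here, the only guide is the span of the two known numbers. Compound 1 at 539 nM sits at the low end of that span, so a move toward weaker inhibition is expected. The estimated size in this assay is a 2.8-fold higher number from compound 1 to compound 3 (0.44 log units; beyond the scatter) and it is expected to lie beyond the scatter, though not with certainty. For compound 3 the estimated value is 1500 nM with an expected range from 500 nM to 4500 nM as the likely span.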

Compound 3, half-maximal inhibitory concentration: 120 nM
Beside the measured number, compound 3's estimate is 13-fold (1.10 log units) above it; measured number below the stated range.
By their numbers in this assay, from the lowest: compound 3; then compound 1; then compound 2.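

In this assay, within the data shown here, hydrogen in place of dimethylamino on this aromatic carbon, para to a large group, gives a 4.5-fold lower number from compound 1 to compound 3 (0.65 log units; beyond the scatter), which is the first direct size for this change at this position. The step shows that dimethylamino is not needed here for inhibition of these cells: the plain phenyl of compound 3 reads as stronger inhibition than the 4-(dimethylamino)phenyl of compound 1, and the difference lies beyond the usual scatter. Nothing in hand bears on the reason for this step.

With only dimethylamino and hydrogen compared at this carbon, the shown compounds leave open how other groups there would read, such as a primary amine, a hydroxyl, a methyl or a carboxylic acid, and so whether the number follows the size of the group or its particular atoms. They also leave open whether the same change gives a step of similar size when the rest of the molecule differs, for example with a chlorine or a nitrile in place of the methoxy group on the sulfonyl-bearing ring.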